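Swapping 4-fluorophenyl for pyridin-2-yl

The compounds below may be only part of what the source reports. "The series", "measured", "known", "first", "only" and "open" are said of these compounds alone.

- Compound 1 `CNC(=O)c1cc(C(=O)N[C@H]2[C@@H]3COC[C@@H]32)cc2c1OC[C@H]2c1cccc(OC)c1`: 3.2
- Compound 2 `CNC(=O)c1cc(C(=O)N[C@H]2[C@@H]3COC[C@@H]32)cc2c1OC[C@H]2c1ccncc1`: 1.3
- Compound 3 `CNC(=O)c1cc(C(=O)N[C@H]2[C@@H]3COC[C@@H]32)cc2c1OC[C@H]2c1ccc(F)cc1`: 3.6

In a physicochemical assay for lipophilicity, at pH 7.4 (on this read-out higher numbers stand for higher lipophilicity and lower numbers for lower lipophilicity), compound 3, at 3.6, stands highest of the three measured compounds. For the measured compounds named here, compound 4 `CNC(=O)c1cc(C(=O)N[C@H]2[C@@H]3COC[C@@H]32)cc2c1OC[C@H]2c1ccccn1` has no measurement yet. It carries pyridin-2-yl in place of 4-fluorophenyl on a saturated ring carbon. The closest guide is the large step of a number 2.30 log units higher from compound 2 to compound 3 (beyond the scatter), which links 4-fluorophenyl with pyridin-4-yl. Read backwards, it points downward. The large step of a number 1.90 log units lower from compound 1 to compound 2 (beyond the scatter) also points downward on entry of pyridin-4-yl, while the modest step of a number 0.40 log units higher from compound 1 to compound 3 (beyond the scatter) involves neither pyridinyl group. Pyridin-2-yl itself remains unmeasured, so a large downward step is expected, of uncertain size. The expected change is a number 1.80 log units lower from compound 3 to compound 4 (beyond the scatter). The estimated value for compound 4 is 1.8, with an expected range from 1.3 to 2.4.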

Compound 4, distribution coefficient: 1.6
Compound 4: the middle estimate sits 0.20 log units above what was measured; measured number inside the range.
By their numbers in this assay, from the lowest: compounds 2 and 4 (each within the scatter of the next); then compound 1; then compound 3.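

Replacing 4-fluorophenyl with pyridin-2-yl gives a number 2.00 log units lower from compound 3 to compound 4 (beyond the scatter) in this assay, and replacing 3-methoxyphenyl with it gives a number 1.60 log units lower from compound 1 to compound 4 (beyond the scatter), so the large fall seen with pyridin-4-yl is not confined to that one pyridinyl group. The two pyridinyl groups differ only by a number 0.30 log units higher from compound 2 to compound 4 (within the scatter), so this read-out does not separate them on this saturated ring carbon. Nothing available explains the fall. On these data alone, what pyridin-3-yl or a saturated amine such as piperidin-4-yl would give on this carbon remains open.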